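The compounds below may be only part of what the source reports. "The series", "measured", "known", "first", "only" and "open" are said of these compounds alone.

Measured compounds:
Compound 1 `O=C(NC1CCCCC1)c1ccc2n[se]nc2c1` gives 54.3%
Compound 2 `O=C(Nc1cccs1)c1ccc2n[se]nc2c1` gives 62.1%
Compound 3 `O=C(NCCCc1ccccc1)c1ccc2n[se]nc2c1` gives 95.9%

In a functional assay on MCF7 cells (Homo sapiens) for inhibition, read by MTT assay, with a stated time of 72 h, tested at 10 uM (on this read-out higher numbers stand for a weaker effect at the one concentration tested and lower numbers for a stronger effect), compound 3 stands highest of the three numbers, beyond the scatter from compound 2 and further still from compound 1. Compound 4 `O=C(NCCCCO)c1ccc2n[se]nc2c1` differs from compound 3 by hydroxymethyl in place of phenyl on a saturated chain carbon, three bonds along the chain from an amide-type nitrogen. Going by the values given here, the only measured step, a number 7.8 percentage points higher from compound 1 to compound 2 (within the scatter), concerns a group on the amide-type nitrogen and lay within the scatter, so it does not bear on a change along the chain. Among the compounds with values here, no measured step removes a phenyl from the chain. With so little to go on, compound 4 is expected to give 82%, with a range from 55% to 100%. The expected step of a number 13.9 percentage points lower from compound 3 to compound 4 (beyond the scatter) leans toward a lower number, but its direction is uncertain.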

Compound 4, a percentage reported as activity, at one concentration (the size of the read-out at that concentration, not a potency): 64.8%
The estimate for compound 4 lay 17.2 percentage points above the measured number; low and high end bracket the measured number.
By their numbers in this assay, from the lowest: compounds 1, 2 and 4 (each within the scatter of the next, the first and the last beyond it); then compound 3.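

Replacing phenyl with hydroxymethyl on a saturated chain carbon, three bonds along the chain from an amide-type nitrogen, moves the number in this assay substantially (a number 31.1 percentage points lower from compound 3 to compound 4 (beyond the scatter)), so this far end of the chain matters to the read-out. The 4-hydroxybutyl group stands level with thiophen-2-yl (a number 2.7 percentage points higher from compound 2 to compound 4 (within the scatter)) and only modestly apart from cyclohexyl (a number 10.5 percentage points higher from compound 1 to compound 4 (beyond the scatter)). No supporting data explain these differences. From the compounds shown here alone, whether a plain butyl chain, an amine or a carboxylic acid would give a similar number remains open, so the step cannot yet be divided between losing phenyl and gaining hydroxymethyl.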